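Replacing chloro with hydrogen in compound 1

The source may report more compounds than this note shows. Statements on the series, on what has been measured and on what is new or still open speak of the compounds shown alone.

In a functional assay on thoracic aorta (Rattus norvegicus, strain Wistar), with a stated time of 15 min (on this read-out lower numbers stand for an effect already at smaller amounts and higher numbers for an effect only at larger amounts of compound), compound 1 (`CC(NC(=O)NS(=O)(=O)c1ccc(Cl)cc1)c1cc(Br)ccc1OCc1ccccc1`) gives 57500 nM. Compound 2 (`Cc1ccc(OCc2ccccc2)c(C(C)NC(=O)NS(=O)(=O)c2ccc(Cl)cc2)c1`) gives 65300 nM and compound 3 (`CC(NC(=O)N(C)S(=O)(=O)c1ccc(Cl)cc1)c1cc(Br)ccc1OCc1ccccc1`) gives 146000 nM, so compound 1 shares the low end of these numbers with compound 2. Compound 4 (`CC(NC(=O)NS(=O)(=O)c1ccccc1)c1cc(Br)ccc1OCc1ccccc1`) differs from compound 1 by hydrogen in place of chloro on an aromatic carbon. Among the compounds with values here, no measured step covers this exchange. The closest guide, methyl in place of bromo on an aromatic carbon, gave a 1.1-fold higher number from compound 1 to compound 2 (0.06 log units; within the scatter). Methyl in place of hydrogen on an amide-type nitrogen gave a 2.5-fold higher number from compound 1 to compound 3 (0.40 log units; beyond the scatter), a modest step at a different place. The expected change is a 1.2-fold higher number from compound 1 to compound 4 (0.09 log units; within the scatter), within the scatter. The estimate for compound 4 is 70000 nM, with an expected range of 30000 nM to 160000 nM.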

Compound 4, half-maximal effective concentration: 130000 nM
For compound 4 the middle estimate is 1.9-fold (0.27 log units) below the measured one; low and high end bracket the measured number.
By their numbers in this assay, from the lowest: compounds 1, 2, 4 and 3 (each within the scatter of the next, the first and the last beyond it).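

The step from (4-chlorophenyl)sulfonyl to phenylsulfonyl gives a 2.3-fold higher number from compound 1 to compound 4 (0.35 log units; beyond the scatter) in this assay. Losing this single chlorine atom therefore moves the number beyond the scatter, whereas the exchange on the other aromatic ring, a 1.1-fold higher number from compound 1 to compound 2 (0.06 log units; within the scatter), did not. Nothing available explains why the chloro matters at this position.

The compounds shown leave open whether fluoro, methoxy or an amine at this place would match chloro or hydrogen. They also leave open whether removing chloro has a similar effect when methyl replaces bromo.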